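Working notes on three measured amides and one analogue

This account rests on a few compounds, and the source may have more. Where it says the series, first, only, none or still open, it means among the compounds named here.

Measured so far:
compound 1 `O=C(OCc1ccccc1)[C@@H]1CCCN1C(=O)CN(c1nc(Cl)nc2[nH]cnc12)C1CC1`: 31.1%
compound 2 `C[C@@H](O)[C@H](NC(=O)CN(c1nc(Cl)nc2[nH]cnc12)C1CC1)C(=O)O`: 24%
compound 3 `CC[C@H](C)[C@H](NC(=O)CN(c1nc(Cl)nc2[nH]cnc12)C1CC1)C(=O)OCc1ccccc1`: 6.9%

All three numbers come from a functional assay on the whole organism (Tail, strain ICR) with Mus musculus as the target, in the tail flick test, with a stated time of 150 min, at a dose of 25 umol/kg by the oral route; on this read-out higher numbers stand for a stronger effect at the one dose given and lower numbers for a weaker effect. Compound 2 stands second highest of the three. Its nearest neighbour is compound 1, whose number lies higher by an amount within the scatter, so the two cannot be ordered. Its furthest neighbour is compound 3, whose number lies lower by an amount beyond the scatter.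

Compound 4 `O=C(O)C[C@H](NC(=O)CN(c1nc(Cl)nc2[nH]cnc12)C1CC1)C(=O)O` is not yet measured. It differs from compound 2 as follows: carboxymethyl in place of 1-hydroxyethyl on a saturated chain carbon bound to an amide-type nitrogen and a carbonyl carbon. Within the data shown here, no pair of measured compounds differs in one place only, so the series offers no step of the same kind to lean on; the free acid of compound 2 is kept in compound 4.

Given that, the expected step in this assay from compound 2 to compound 4 is a number 3 percentage points lower from compound 2 to compound 4 (within the scatter), that is, none beyond the scatter. Compound 4 is therefore estimated at 21%, with a range from 8% to 34%.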

Compound 4, a percentage reported as activity, at one dose (the size of the read-out at that dose, not a potency): 11.6%
The estimate for compound 4 lay 9.4 percentage points above the measured number, within the range that was stated.
By their numbers in this assay, from the lowest: compounds 3 and 4 (each within the scatter of the next); then compounds 2 and 1 (each within the scatter of the next).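

In this assay, among these compounds, carboxymethyl in place of 1-hydroxyethyl on a saturated chain carbon bound to an amide-type nitrogen and a carbonyl carbon gives the first single-place step (a number 12.4 percentage points lower from compound 2 to compound 4 (beyond the scatter)) and so shows that the number responds to a change at this position. The two groups each carry 1 hydrogen-bond donor and 1 hydrogen-bond acceptor, so the step appears with those counts unchanged. No measurement at hand accounts for the step.

On these data alone, whether an amine at the same place, or a longer chain ending in a carboxylic acid, would hold the number of compound 2 remains open. Steps involving compound 1 or compound 3 cannot be read, as each differs from the other compounds in more than one place.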